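This account rests on a few compounds, and the source may have more. Where it says the series, first, only, none or still open, it means among the compounds named here.

Of the compounds shown here, three built on one shared core have been tested in an assay on isolated protein for inhibition of Fatty-acid amide hydrolase 1 (Homo sapiens); on this read-out lower numbers stand for stronger inhibition and higher numbers for weaker inhibition. Compound 1 `CC(C)C(=O)N1CCC(CCCC(=O)c2ncco2)CC1` gives 250 nM. For the measured compounds named here, compound 2 `CC(C)(C)CC(=O)N1CCC(CCCC(=O)c2ncco2)CC1` gives 90 nM, and the only single-point step among the measured compounds is a 2.8-fold lower number from compound 1 to compound 2 (0.44 log units; beyond the scatter). Compound 3 `COc1cccc(CN2CCC(CCCC(=O)c3ncco3)CC2)c1` gives 34 nM, the lowest of the three numbers, with gaps to compound 2 and to compound 1 that both lie beyond the usual scatter.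

Compound 4 `O=C(CCCC1CCN(Cc2ccc(Br)cc2)CC1)c1ncco1` has not been measured. It differs from compound 3 in one place: 4-bromophenyl in place of 3-methoxyphenyl on a saturated chain carbon bound to an amine nitrogen in a ring. Going by the values given here, none of the measured steps bears on this part of the molecule. Among the compounds with values here, the one step with a known size altered a group on a carbonyl carbon, at the other end of the core, and it does not tell how exchanging one aromatic ring for another on the saturated chain carbon bound to the ring nitrogen will act. Within the data shown here, with no step to lean on, the plain expectation is that compound 4 stays close to compound 3, with an expected step of a 1.2-fold higher number from compound 3 to compound 4 (0.07 log units; within the scatter) that is not beyond the scatter. For compound 4 the value expected in this assay is 40 nM, within a range from 12 nM to 130 nM.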

Compound 4, half-maximal inhibitory concentration: 45 nM
Estimate against measurement, compound 4: 1.1-fold (0.05 log units) below, within the range that was stated.
By their numbers in this assay, from the lowest: compounds 3, 4 and 2 (each within the scatter of the next, the first and the last beyond it); then compound 1.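

In this assay, for the compounds shown here, the change from 3-methoxyphenyl to 4-bromophenyl on the saturated chain carbon bound to the ring nitrogen leaves no readable difference (a 1.3-fold higher number from compound 3 to compound 4 (0.12 log units; within the scatter)), even though the hydrogen-bond acceptor counted in the leaving group has no counterpart in the entering one. Replacing the whole group on the ring nitrogen gives a mixed picture: 4-bromobenzyl cannot be told apart from neopentylcarbonyl (a 2.0-fold lower number from compound 2 to compound 4 (0.30 log units; within the scatter)), but it stands clearly apart from isopropylcarbonyl (a 5.6-fold lower number from compound 1 to compound 4 (0.74 log units; beyond the scatter)), so the benzyl type of group is not tied to a single substituent and the isopropyl amide remains the clear outlier among these pairs. No measurement at hand explains any of these results.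

The exchange alters both the substituent and its place on the aromatic ring, so the two effects cannot be separated here, and 3-bromophenyl or 4-methoxyphenyl would be needed to pull them apart. Going by these compounds, how far this tolerance extends also stays open, since an unsubstituted phenyl or a pyridine ring in the same place could behave quite differently.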